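Hydrogen for methyl at the assay limit

The source may report more compounds than this note shows. Statements on the series, on what has been measured and on what is new or still open speak of the compounds shown alone.

Compound 1 `O=C(N/N=C/c1coc2ccc(O)cc2c1=O)c1cc2ccccc2[nH]1`: > 200000 nM
Compound 2 `Cc1ccc2occ(/C=N/NC(=O)c3cc4ccccc4[nH]3)c(=O)c2c1`: > 200000 nM

Both results come from a toxicity assay on HepG2 cells (Homo sapiens) for cytotoxicity, read by CCK-8 assay, with a stated time of 24 h (a lower number here means that less compound is tolerated, a higher number that more compound is tolerated), and neither is an exact number. Compound 1 gives > 200000 nM as a limit of the assay. Compound 2 gives > 200000 nM as a limit too. The record so far is the limit of > 200000 nM in this assay, at which 2 of the 2 values shown sit, with no exact figure yet.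

Compound 3 `O=C(N/N=C/c1coc2ccccc2c1=O)c1cc2ccccc2[nH]1` differs from compound 2 by hydrogen in place of methyl on an aromatic carbon. Within the data shown here, the only measured step that bears on this, also a swap on an aromatic carbon, is a step that the two limits leave unreadable from compound 1 to compound 2 and it offers no size to carry over. Compound 2 at > 200000 nM remains the only anchor, so no step beyond the usual scatter is expected in this assay and no direction is favoured. The expected move is a number no higher from compound 2 to compound 3 (the limit leaves the size open) and another limit is the likeliest report. Compound 3 is estimated at 200000 nM (expected range 100000 nM to 400000 nM).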

Compound 3, half-maximal cytotoxic concentration: > 200000 nM
Compound 3: a limit, no number; the forecaster's own chance of this, stated with the estimate: 85%; the middle value lies on the limit itself.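

Among these compounds, the results of compound 1, compound 2 and compound 3 in this assay are all limits, not numbers, and no step between them can be read. Still open, as far as these compounds go, is how much of each compound the cells tolerate, and whether hydroxy, methyl or hydrogen on that aromatic carbon makes any difference.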